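A few compounds are considered here, and "the series" means these few. Any claim that something is new, unique, unknown or untested is made for them only; others in the source may bear on it.

Three urea compounds share one core and have been tested in an ADME assay on the whole organism with Oryza sativa as the target, tested at 0.1 uM; a higher number here means a weaker effect of the compound at the concentration tested, a lower number a stronger effect. Compound 1, `C[C@H](NC(=O)Nc1ccc(C(C)(C)C)cc1)c1ccccc1`, gives 100%. Compound 2, `CCCCCc1ccc(NC(=O)N[C@H](C)c2ccccc2)cc1`, gives 100%. Compound 3, `CCCCCc1ccc(NC(=O)N[C@@H](C)c2ccccc2)cc1`, gives 98%. Compound 3 cannot be told apart from either neighbour: the change of pentyl in place of tert-butyl on an aromatic carbon gives a number 2 percentage points lower from compound 1 to compound 3 (within the scatter), and the change of configuration alone gives a number 2 percentage points lower from compound 2 to compound 3 (within the scatter), which follows from the fact that compounds 2 and 3 differ only in the configuration as drawn.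

Compound 4, `CC(=O)c1ccc(NC(=O)N[C@@H](C)c2ccccc2)cc1`, has not yet been measured. It differs from compound 3 by acetyl in place of pentyl on an aromatic carbon. For the measured compounds named here, only one measured step touches the same aromatic carbon, the swap of pentyl for tert-butyl, and that step stayed within the scatter; the configuration step did the same. Both steps point to a shared core that tolerates such swaps without a change beyond the scatter, though an acetyl group was not among them. Compound 4 is therefore expected to give 95% in this assay, between 75% and 100%, which is expected to mean a number 3 percentage points lower from compound 3 to compound 4 (within the scatter).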

Compound 4, a percentage reported as activity, at one concentration (the size of the read-out at that concentration, not a potency): 99%
The estimate for compound 4 lay 4 percentage points below the measured number; the range from low to high includes it.
By their numbers in this assay, from the lowest: compounds 3, 4, 1 and 2 (each within the scatter of the next).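

In this assay, acetyl in place of pentyl on the same aromatic carbon gives a number 1 percentage points higher from compound 3 to compound 4 (within the scatter), and acetyl in place of tert-butyl gives a number 1 percentage points lower from compound 1 to compound 4 (within the scatter). For the compounds shown here, the earlier swap at this carbon exchanged one all-carbon group for another, whereas acetyl brings an oxygen, a hydrogen-bond acceptor and a double bond outside aromatic rings, and still no step leaves the scatter. Nothing at hand offers a reason for this result.

The compounds shown give no step at this carbon that goes beyond the scatter, so they do not show whether any group placed here can move the number that far. From the compounds shown here alone, whether an amine or a carboxylic acid on this carbon would also stay within the scatter remains open.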